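This account rests on a few compounds, and the source may have more. Where it says the series, first, only, none or still open, it means among the compounds named here.

Working notes on the series.

Compound 3 `CC(C)(C)OC(=O)CC[C@H]1N=C2C[C@H]3C[C@H](C3(C)C)[C@@]2(C)OC1=O` gives 55000 nM in a functional assay on PC-3 cells (Homo sapiens) for antiproliferative activity, read by sulforhodamine B assay, with a stated time of 48 h; a lower number here means a stronger inhibitor, a higher number a weaker inhibitor. Among the compounds with values here, that places it second highest of the three numbers so far: compound 1 `CC1(C)[C@@H]2CC3=N[C@@H](CCC(=O)O)C(=O)O[C@@]3(C)[C@H]1C2` gives 42000 nM and sits within the scatter of compound 3, while compound 2 `C[C@@H]1N=C2C[C@@H]3C[C@@H](C3(C)C)[C@]2(C)OC1=O` gives 149000 nM, beyond the scatter above both.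

Compound 4 `CC(C)(C)OC(=O)CC[C@@H]1N=C2C[C@@H]3C[C@@H](C3(C)C)[C@]2(C)OC1=O` differs from compound 3 as follows: the two compounds have the same atoms and bonds and differ only in configuration as drawn: 4 of 4 stereo elements differ (all stereocentres are inverted: mirror images); a stereocentre at a saturated ring carbon is drawn R in compound 3 and S in compound 4; a stereocentre at a saturated ring carbon is drawn R in compound 3 and S in compound 4; a stereocentre at a saturated ring carbon is drawn R in compound 3 and S in compound 4; a stereocentre at a saturated ring carbon is drawn R in compound 3 and S in compound 4.

Within the data shown here, the only step between measured compounds, a 3.5-fold higher number from compound 1 to compound 2 (0.55 log units; beyond the scatter), concerns removal of a carboxymethyl group and does not bear on an inversion of configuration. Among the measured compounds shown here, no measured pair shows what mirror-image configuration does in this assay, so no direction can be read from the data; the expectation is a step of a 1.1-fold higher number from compound 3 to compound 4 (0.04 log units; within the scatter), within the scatter, with a wide range.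

Compound 4 is expected to give about 60000 nM, between 15000 nM and 250000 nM.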

Compound 4, half-maximal inhibitory concentration: 42000 nM
Compound 4: middle estimate off by 1.4-fold (0.15 log units), on the high side, within the range that was stated.
By their numbers in this assay, from the lowest: compounds 1, 4 and 3 (each within the scatter of the next); then compound 2.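

In this assay, within the data shown here, the mirror-image pair gives the first reading of configuration, and a 1.3-fold lower number from compound 3 to compound 4 (0.12 log units; within the scatter) shows no separation of the two, in a comparison that isolates configuration alone: the fact that compounds 3 and 4 differ only in the configuration as drawn. Tert-butyl in place of hydrogen on an oxygen next to a carbonyl group likewise gives no change at the digits printed from compound 1 to compound 4 (within the scatter). The chain still counts, since (tert-butoxycarbonyl)methyl in place of hydrogen gives a 3.5-fold lower number from compound 2 to compound 4 (0.55 log units; beyond the scatter) and so matches the earlier carboxymethyl step in size.

Open, from the compounds shown here alone, is whether an amide, a primary amine or a longer chain at this position would move the number further.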